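The source may hold more compounds than are shown below. What is called first, only, known or untested is meant among the compounds shown, and "the series" means these compounds.

In a functional assay on the whole organism (strain Wistar albino) for inhibition, with Rattus norvegicus as the target, read by paw edema, with a stated time of 1 h, at a dose of 40 mg/kg by the oral route (a higher number here means more inhibition at the dose given (going by the name of the read-out), a lower number less inhibition), compound 3 `Cc1nc(-c2ccc(Cl)cc2)sc1C1SCC(=O)N1c1ccc(F)cc1` gives 63.4%, the largest of the three numbers, although its neighbours sit within the usual scatter: compound 2 `Cc1ccc(N2C(=O)CSC2c2sc(Cc3ccc(Cl)cc3)nc2C)cc1` gives 59.9% and compound 1 `Cc1nc(-c2ccc(Cl)cc2)sc1C1SCC(=O)N1c1ccc(F)c(Cl)c1` gives 53.4%. Compound 4 `Cc1ccc(N2C(=O)CSC2c2sc(-c3ccc(Cl)cc3)nc2C)cc1` has not yet been measured in this assay. It differs from compound 3 by methyl in place of fluoro on an aromatic carbon. Among the measured compounds shown here, the only measured step that bears on this change is also a swap of a single substituent on an aromatic carbon, a number 10 percentage points higher from compound 1 to compound 3 (within the scatter), and it stayed within the scatter. By that precedent, no step beyond the scatter is expected, so compound 4 is estimated to lie close to compound 3, with a number 1.4 percentage points lower from compound 3 to compound 4 (within the scatter) and a value of about 62% expected, between 50% and 74%.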

Compound 4, a percentage reported as inhibition, in the whole organism at one dose (the size of the read-out at that dose, not a potency): 38.3%
Estimate against measurement, compound 4: 23.7 percentage points above; the whole stated range lies above it.
By their numbers in this assay, from the lowest: compound 4; then compounds 1, 2 and 3 (each within the scatter of the next).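

In this assay, among the compounds shown here, methyl in place of fluoro on an aromatic carbon para to a large group gives a number 25.1 percentage points lower from compound 3 to compound 4 (beyond the scatter), the first step here beyond the scatter, so a swap at this position can move the number. Compound 4 also falls away from the other two: 4-chlorophenyl in place of 4-chlorobenzyl gives a number 21.6 percentage points lower from compound 2 to compound 4 (beyond the scatter), and 4-methylphenyl in place of 3-chloro-4-fluorophenyl on the amide-type nitrogen gives a number 15.1 percentage points lower from compound 1 to compound 4 (beyond the scatter). No measurement on hand accounts for these steps. On these data alone, whether methoxy, an amine or a longer chain at this position would read closer to fluoro or to methyl stays open.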